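Trifluoromethyl Moved to a Third Place on the Ring

The compounds below may be only part of what the source reports. "The series", "measured", "known", "first", "only" and "open" are said of these compounds alone.

Compound 1 `CC1=C(/C=C/C(=O)/C=C/c2ccccc2)C(C)(C)CCC1O` is the parent of this small set. In a functional assay on LNCaP cells (Homo sapiens) for cytotoxicity, read by MTT assay, with a stated time of 72 h (a higher number here means a weaker inhibitor, a lower number a stronger inhibitor), compound 1 gives 5800 nM, the highest of the three numbers measured. Two trifluoromethyl analogues follow it. Compound 2 `CC1=C(/C=C/C(=O)/C=C/c2ccccc2C(F)(F)F)C(C)(C)CCC1O` gives 2900 nM, and compound 3 `CC1=C(/C=C/C(=O)/C=C/c2cccc(C(F)(F)F)c2)C(C)(C)CCC1O` gives 740 nM. The step of a 2.0-fold lower number from compound 1 to compound 2 (0.30 log units; within the scatter) stays within the scatter, whereas the step of a 7.8-fold lower number from compound 1 to compound 3 (0.89 log units; beyond the scatter) goes beyond it. Compound 4 `CC1=C(/C=C/C(=O)/C=C/c2ccc(C(F)(F)F)cc2)C(C)(C)CCC1O` carries the same group at a third place: trifluoromethyl in place of hydrogen on an aromatic carbon. Both measured steps bear on this change, since each adds the same group to the same ring; one was small and one modest, and both went toward a lower number. The expected step is therefore a 4.5-fold lower number from compound 1 to compound 4 (0.65 log units; beyond the scatter), lying between the two measured ones. Compound 4 is estimated at 1300 nM, with a range from 400 nM to 4000 nM.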

Compound 4, half-maximal inhibitory concentration: 3000 nM
Beside the measured number, compound 4's estimate is 2.3-fold (0.36 log units) below it, within the range that was stated.
By their numbers in this assay, from the lowest: compound 3; then compounds 2, 4 and 1 (each within the scatter of the next).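

In this assay the change at this place, para to a large group, comes to a 1.9-fold lower number from compound 1 to compound 4 (0.29 log units; within the scatter), so adding trifluoromethyl here leaves the number no different from that of the parent. Going by these compounds alone, the earlier steps could not show whether the lower number of compound 3 came with the group on any carbon of this ring; now a 7.8-fold lower number from compound 1 to compound 3 (0.89 log units; beyond the scatter) stands as the only one of the three steps beyond the scatter, so the effect is tied to that one place and not to trifluoromethyl on the ring as such. Nothing given here accounts for this difference between the places.

The compounds shown leave open whether a methoxy group, a chlorine atom or an amine would follow the same dependence on place. They also leave open whether a second trifluoromethyl on the ring would change the number further.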